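Swapping a ring amine for a fluorinated ether chain

The source may report more compounds than this note shows. Statements on the series, on what has been measured and on what is new or still open speak of the compounds shown alone.

Compound 1 `CN(Cc1cc(C(F)(F)F)cc(C(F)(F)F)c1)C(=O)c1c(OCCCC2CCCCC2)c2ccccc2n(C)c1=O`: 190 nM
Compound 2 `CN(Cc1cc(C(F)(F)F)cc(C(F)(F)F)c1)C(=O)c1c(N2CCCCC2)c2ccccc2n(C)c1=O`: "not determined" (no result reported)

Compound 1 was tested in an assay for inhibition of phosphatidylcholine:ceramide cholinephosphotransferase 2 (Mus musculus), read by mass spectrometry, with stated times of 60 min and 30 min (on this read-out higher numbers stand for weaker inhibition and lower numbers for stronger inhibition), and gives 190 nM. For the measured compounds named here, compound 2 shares the core of compound 1 but carries a piperidin-1-yl group where compound 1 has its ether chain; for compound 2 the result in this assay reads "not determined" (no result reported), so it cannot be placed on the scale at all, and no measured step leads from it to anything else.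

Compound 3 `CN(Cc1cc(C(F)(F)F)cc(C(F)(F)F)c1)C(=O)c1c(OCCCC(F)(F)F)c2ccccc2n(C)c1=O` is the next variation on the same carbon: 4,4,4-trifluorobutoxy in place of piperidin-1-yl on an aromatic carbon. With compound 2 blank, the size and direction of the change from compound 2 to compound 3 in this assay cannot be stated; what remains is the comparison with compound 1, which also bears an ether chain on that aromatic carbon. Because compound 1 gives 190 nM, compound 3 is expected to land in a similar region, if anything somewhat weaker. Compound 3 is estimated at about 450 nM, with a range from 120 nM to 2000 nM.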

Compound 3, half-maximal inhibitory concentration: 240 nM
The estimate for compound 3 lay 1.9-fold (0.27 log units) above the measured number; the range from low to high includes it.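

In this assay, trifluoromethyl in place of cyclohexyl on a saturated chain carbon, three bonds along the chain from an oxygen on an aromatic ring, gives a 1.3-fold higher number from compound 1 to compound 3 (0.10 log units; within the scatter) and so separates the two compounds by no more than the usual scatter. For the compounds shown here, this is the first measured step at this position, and it shows that the number does not depend on the cyclohexyl group: the two ether chains, one ending in that ring and the other in trifluoromethyl, read alike on this aromatic carbon. Nothing measured here bears on why they read alike.

Any step to or from compound 2 cannot be read, so whether a ring amine such as piperidin-1-yl on this carbon compares with either ether chain remains unknown. Also open, on these data alone, is how far the chain itself can vary, whether a short methoxy group, a longer chain or a chain ending in a carboxylic acid would stay in the same region, since both measured compounds carry an ether oxygen and the same chain length up to the terminal group.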